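Notes on compound 4: fluoro in place of nitro

The source may hold more compounds than are shown below. What is called first, only, known or untested is meant among the compounds shown, and "the series" means these compounds.

Measured so far in a functional assay on A549 cells (Homo sapiens) for antiproliferative activity, read by XTT assay, with a stated time of 24 h; a higher number here means a weaker inhibitor, a lower number a stronger inhibitor:
compound 1 `Cc1ccc(-c2csc(N3N=C(c4ccc(C)s4)CC3c3ccc(F)cc3)n2)cc1` — > 500 ug/mL
compound 2 `Cc1ccc(C2=NN(c3nc(-c4ccc([N+](=O)[O-])cc4)cs3)C(c3ccc(F)cc3)C2)s1` — 16.7 ug/mL
compound 3 `O=[N+]([O-])c1ccc(-c2csc(N3N=C(c4ccc(Cl)s4)CC3c3ccc(F)cc3)n2)cc1` — > 500 ug/mL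

The values of compound 1 and compound 3 are limits of the assay, not numbers. Compound 3 therefore stands at the limit, as the limit of > 500 ug/mL in this assay, at which 2 of the 3 values shown sit, records. Two steps are known: an at least 29-fold lower number from compound 1 to compound 2 (1.47 log units; beyond the scatter) and an at least 29-fold higher number from compound 2 to compound 3 (1.47 log units; beyond the scatter). Compound 4 is `Fc1ccc(-c2csc(N3N=C(c4ccc(Cl)s4)CC3c3ccc(F)cc3)n2)cc1`; its change from compound 3 is fluoro in place of nitro on an aromatic carbon. Going by the values given here, no measured step tests fluoro against nitro. The arrival of nitro in the step from compound 1 to compound 2 went with a large fall, so its departure gives no ground to expect a lower number for compound 4, and compound 3 already sits at the limit. Compound 4 is expected to stay at the limit, a number no higher from compound 3 to compound 4 (the limit leaves the size open), estimated at 500 ug/mL within 150 ug/mL to 1000 ug/mL.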

Compound 4, half-maximal inhibitory concentration: > 500 ug/mL
Compound 4 gave a limit, no number (the forecaster's own chance of this, stated with the estimate: 75%); the middle value lies on the limit itself.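

The step from compound 3 to compound 4 cannot be read, since both values in this assay are limits of the assay: the limit of > 500 ug/mL in this assay, at which 3 of the 4 values shown sit. The compounds shown leave open how 4-nitrophenyl and 4-fluorophenyl compare in this chloro-bearing pair.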